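Amide substituent variation in a kinase-binding series

A few compounds are considered here, and "the series" means these few. Any claim that something is new, unique, unknown or untested is made for them only; others in the source may bear on it.

Measured so far:
compound 1, `Cn1cc(-c2cnc3c(-c4csc(C(=O)N[C@@H]5CCC[C@H]5N)c4)cnn3c2)cn1`, 3 nM
compound 2, `Cn1cc(-c2cnc3c(-c4csc(C(=O)NC(CO)C5CC5)c4)cnn3c2)cn1`, 9 nM

In an assay for inhibition of MAP/microtubule affinity-regulating kinase 3 (Homo sapiens), read by HTRF, with a stated time of 2 h (on this read-out higher numbers stand for weaker inhibition and lower numbers for stronger inhibition), compound 2 gives the higher of the two numbers recorded; compound 1 gives the lower one, and the step of a 3.0-fold higher number from compound 1 to compound 2 (0.48 log units; beyond the scatter) is modest but beyond the scatter.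

Compound 3, `Cn1cc(-c2cnc3c(-c4csc(C(=O)N[C@@H]5CCCC[C@@H]5O)c4)cnn3c2)cn1`, is not yet measured. It differs from compound 2 by a group of 7 heavy atoms (6 carbon, 1 oxygen; one six-membered non-aromatic ring of carbon only) in place of a group of 6 heavy atoms (5 carbon, 1 oxygen; one three-membered non-aromatic ring of carbon only), on an amide-type nitrogen. Going by the values given here, only one measured step concerns the amide-type nitrogen, a 3.0-fold higher number from compound 1 to compound 2 (0.48 log units; beyond the scatter), in which a non-aromatic ring bearing an amine gave way to an open group with a hydroxyl; that step was modest. Among the compounds with values here, no measured pair shows a ring bearing a hydroxyl at this position, so the expectation rests on that single step alone.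

Compound 3 is therefore expected to land close to compound 2, with a step of a 1.5-fold lower number from compound 2 to compound 3 (0.18 log units; within the scatter) that need not exceed the scatter. The estimate for compound 3 in this assay is 6 nM, with a range of 2 nM to 20 nM.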

Compound 3, half-maximal inhibitory concentration: 9 nM
Compound 3: the middle estimate sits 1.5-fold (0.18 log units) below what was measured, within the range that was stated.
By their numbers in this assay, from the lowest: compound 1; then compounds 2 and 3 (each within the scatter of the next).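

In this assay, the 2-hydroxycyclohexyl group on the amide-type nitrogen gives no change at the digits printed from compound 2 to compound 3 (within the scatter), so this hydroxyl-bearing six-membered ring and the open hydroxyl group with its three-membered ring cannot be told apart at this position. Set against the amine-bearing five-membered ring, the new group gives a 3.0-fold higher number from compound 1 to compound 3 (0.48 log units; beyond the scatter), the same size as a 3.0-fold higher number from compound 1 to compound 2 (0.48 log units; beyond the scatter), so both hydroxyl-bearing groups now stand at the same distance from compound 1. Nothing available gives a reason for these numbers.

Compound 3 differs from compound 1 in both ring size and in hydroxyl for amine, and these two changes cannot be separated here. As far as these compounds go, a 2-aminocyclohexyl group or a 2-hydroxycyclopentyl group on the same nitrogen would change only one of them, and the effect of each remains open.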